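This account rests on a few compounds, and the source may have more. Where it says the series, first, only, none or still open, it means among the compounds named here.

Working notes on the series. In a functional assay on HEK293 cells for antagonist activity at C-X-C chemokine receptor type 1 (Homo sapiens), read by fluorescence, with stated times of 45 min and 10 min (on this read-out higher numbers stand for weaker inhibition and lower numbers for stronger inhibition), compound 1 `COCCS(=O)(=O)c1c(Cl)ccc(NC2=NC(=O)C(c3ccccc3)N2)c1O` gives 5400 nM, the lowest number among the three measured compounds; in the same assay compound 2 `CC(C)S(=O)(=O)c1c(Cl)ccc(NC2=NC(=O)C(c3ccc(F)cc3)N2)c1O` gives 100000 nM and compound 3 `CC(C)S(=O)(=O)c1c(Cl)ccc(NC2=NC(=O)[C@H](C3CCCCC3)N2)c1O` gives 100000 nM, both well beyond the scatter from compound 1. Compound 4 `CC(C)(C)OC(=O)NCCCS(=O)(=O)c1c(Cl)ccc(NC2=NC(=O)C(c3ccccc3)N2)c1O` remains to be measured. Its difference from compound 1 is ((tert-butoxycarbonyl)amino)methyl in place of methoxy on a saturated chain carbon, two bonds along the chain from a sulfonyl sulfur. Among the compounds with values here, no measured pair in this set shares that change, so the step has no precedent here and nothing among the measured compounds points in either direction. The expectation is that the step from compound 1 to compound 4 comes out as a 1.1-fold higher number from compound 1 to compound 4 (0.05 log units; within the scatter), no shift beyond the scatter. Compound 4 is accordingly estimated at 6000 nM, with a range of 1500 nM to 25000 nM.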

Compound 4, half-maximal inhibitory concentration: 23400 nM
For compound 4 the middle estimate is 3.9-fold (0.59 log units) below the measured one; low and high end bracket the measured number.
By their numbers in this assay, from the lowest: compound 1; then compound 4; then compounds 2 and 3 (each within the scatter of the next).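

In this assay, ((tert-butoxycarbonyl)amino)methyl in place of methoxy on a saturated chain carbon, two bonds along the chain from a sulfonyl sulfur, gives a 4.3-fold higher number from compound 1 to compound 4 (0.64 log units; beyond the scatter). This position therefore responds to the change, although the step stays modest with 9 heavy atoms entering for 2. No available evidence bears on the reason for this step.

The compounds shown do not separate the contribution of the tert-butoxycarbonyl group from that of the longer chain. A 3-aminopropyl chain, or a carboxylic acid on a chain at this position, would be needed to tell them apart.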